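A few compounds are considered here, and "the series" means these few. Any claim that something is new, unique, unknown or untested is made for them only; others in the source may bear on it.

In a functional assay on HCT-8 cells (Homo sapiens) for cytotoxicity (on this read-out lower numbers stand for an effect already at smaller amounts and higher numbers for an effect only at larger amounts of compound), compound 1 `COC1=C(C)C(=O)/C(=C(O)/C=C/c2ccccc2OC)C(=O)C1(C)C` gives 4.1 ug/mL and compound 2 `COC1=C(C)C(=O)/C(=C(O)/C=C/c2c(C)cccc2C)C(=O)C1(C)C` gives 7.8 ug/mL. Among the measured compounds shown here, the only measured step, a 1.9-fold higher number from compound 1 to compound 2 (0.28 log units; within the scatter), places 2,6-dimethylphenyl on the shared core in place of 2-methoxyphenyl. For the measured compounds named here, it stays within the scatter, so compound 2 cannot be separated from the only other measured member of the series.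

Compound 3 `COC1=C(C)C(=O)/C(=C(O)/C=C/c2c(C)cc(C)cc2C)C(=O)C1(C)C` is still unmeasured and carries a single change: methyl in place of hydrogen on an aromatic carbon. The entering methyl sits on an aromatic carbon, meta to two methyl groups and para to a large group. Going by the values given here, no measured pair tests a methyl in place of hydrogen at this place, so the evidence is indirect. The nearest guide is a 1.9-fold higher number from compound 1 to compound 2 (0.28 log units; within the scatter), a change of substituents on the same aromatic ring that did not exceed the scatter. Among the compounds with values here, with only this step to go on, no clear shift in either direction is expected in this assay, and a surprise cannot be ruled out. The expected size of the change is small, with an estimated 1.1-fold lower number from compound 2 to compound 3 (0.05 log units; within the scatter), within the scatter. The estimated value for compound 3 is 7 ug/mL, with an expected range from 3 ug/mL to 15 ug/mL.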

Compound 3, concentration for half-maximal effect: 8.4 ug/mL
Beside the measured number, compound 3's estimate is 1.2-fold (0.08 log units) below it, and the stated range covers the measured number.
By their numbers in this assay, from the lowest: compounds 1, 2 and 3 (each within the scatter of the next, the first and the last beyond it).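

In this assay, methyl in place of hydrogen on the aromatic carbon meta to two methyl groups and para to a large group gives a 1.1-fold higher number from compound 2 to compound 3 (0.03 log units; within the scatter). Among the compounds shown here, this is the first direct test of this position: the earlier step exchanged substituents on the same aromatic ring, whereas here one carbon is added to the ring of compound 2, and the two numbers cannot be told apart. So, in this assay and for this one pair, a methyl at this position is tolerated without a separable effect, and the compounds at hand offer no explanation for that result.

Methyl is the only group shown at this aromatic carbon, so it remains open whether an amine, a carboxylic acid or a longer chain placed there would also stay within the scatter. On these data alone, it is equally open whether the same methyl would read the same way on the 2-methoxyphenyl ring of compound 1.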